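The source may report more compounds than this note shows. Statements on the series, on what has been measured and on what is new or still open speak of the compounds shown alone.

Measured so far in a functional assay on MIA PaCa-2 cells (Homo sapiens) for inhibition, read by MTT assay, with a stated time of 7 days; a higher number here means a weaker inhibitor, a lower number a stronger inhibitor:
- compound 1, `CCCN(CCC)S(=O)(=O)c1ccc(S(=O)(=O)N2CCC[C@@H](C(=O)OCC)C2)cc1`, gives 2300 nM
- compound 2, `CCN(CC)S(=O)(=O)c1ccc(S(=O)(=O)N2CCC[C@@H](C(=O)N(C)C(C)C)C2)cc1`, gives 6200 nM

Of the two numbers in this assay, compound 2 holds the higher one. For the measured compounds named here, its only neighbour is compound 1 with the lower number, and the gap between the two lies beyond the usual scatter. Going by the values given here, the two structures differ in more than one place, so no single step between them is defined and nothing is read into the gap.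

Compound 3, `CCN1CC(NC(=O)[C@@H]2CCCN(S(=O)(=O)c3ccc(S(=O)(=O)N(CC)CC)cc3)C2)C1`, is not yet measured. It differs from compound 2 in one place: (1-ethylazetidin-3-yl)amino in place of isopropyl(methyl)amino on a carbonyl carbon. Among the compounds with values here, no measured pair shows this change, and no pair shows any change at the carbamoyl group at all, so the expectation rests on compound 2 alone, with no direction taken from the data. The expected step of a 1.1-fold lower number from compound 2 to compound 3 (0.05 log units; within the scatter) is therefore set at none beyond the scatter, with a wide band around it. On that basis the estimate for compound 3 in this assay is 5500 nM, with a range from 1500 nM to 20000 nM.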

Compound 3, half-maximal inhibitory concentration: > 30000 nM
Compound 3 gave a limit, no number; the forecaster's own chance of this, stated with the estimate: 15%; middle value at least 5.4-fold (0.73 log units) from the limit.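

For the compounds shown here, at the carbonyl carbon, (1-ethylazetidin-3-yl)amino in place of isopropyl(methyl)amino is the first single-place change that can be read in this assay, and it gives an at least 4.8-fold higher number from compound 2 to compound 3 (0.68 log units; beyond the scatter). This step is a lower bound, and only its direction is fixed, as compound 3 gives a limit of the assay and not a number: the limit of > 30000 nM in this assay, at which 1 of the 3 values shown sits.

The carbamoyl group is therefore a place where one change moves the number beyond the scatter, which compound 1 and compound 2 could not show, as they differ in more than one place.

Open, on these data alone, is which part of the entering group goes with the step: the amide hydrogen, the four-membered ring or the ethyl-bearing ring nitrogen, which a cyclobutylamino or a plain dimethylamino group on the same carbonyl carbon would help to separate. Also open, as far as these compounds go, is how the ethyl ester compares with an amide when the sulfonamide chains are held the same.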